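Carbamate to oxadiazolylmethyl on the piperidine nitrogen

The source may hold more compounds than are shown below. What is called first, only, known or untested is meant among the compounds shown, and "the series" means these compounds.

Measured compounds:
Compound 1, `CC(C)(C)OC(=O)N1CCC(O[C@H]2CC[C@H](Oc3ccc(S(C)(=O)=O)cc3)CC2)CC1`: 16.1 nM
Compound 2, `CS(=O)(=O)c1cnc(O[C@H]2CC[C@H](OC3CCN(C(=O)Oc4ccccc4)CC3)CC2)cn1`: 9.6 nM

Both compounds were tested in a functional assay on isolated protein for agonist activity at Glucose-dependent insulinotropic receptor (Homo sapiens), read by HTRF and cAMP accumulation; on this read-out higher numbers stand for an effect only at larger amounts of compound and lower numbers for an effect already at smaller amounts. Compound 2 holds the lower of the two numbers, but its gap to compound 1 lies within the scatter, so the two show no difference that can be read as real. Compound 3, `CC(C)c1noc(CN2CCC(O[C@H]3CC[C@H](Oc4cnc(S(C)(=O)=O)cn4)CC3)CC2)n1`, is the one not yet measured. It differs from compound 2 in one place: (3-isopropyl-1,2,4-oxadiazol-5-yl)methyl in place of phenoxycarbonyl on an amine nitrogen in a ring. Going by the values given here, no measured pair shows what such a replacement does here, so the expectation rests only on the two numbers above, which sit close to each other regardless of the group carried on this nitrogen. For compound 3 the step of a 1.4-fold lower number from compound 2 to compound 3 (0.14 log units; within the scatter) is expected to stay within the scatter or give a modest gain. Compound 3 is therefore estimated at 7 nM in this assay, with a range from 2 nM to 25 nM.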

Compound 3, half-maximal effective concentration: 14 nM
Estimate against measurement, compound 3: 2.0-fold (0.30 log units) below; the measured number falls inside the stated range.
By their numbers in this assay, from the lowest: compounds 2, 3 and 1 (each within the scatter of the next).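

In this assay, (3-isopropyl-1,2,4-oxadiazol-5-yl)methyl in place of phenoxycarbonyl on the amine nitrogen in the ring gives a 1.5-fold higher number from compound 2 to compound 3 (0.16 log units; within the scatter). Going by these compounds alone, this is the first comparison at this nitrogen that differs in one place only, and it shows that the carbamate carbonyl and the six-membered aromatic ring of carbon only can both leave, with a five-membered aromatic ring with 3 hetero atoms entering, without a change that can be read. Nothing measured on these compounds bears on why the number holds across this change.

Still open, from the compounds shown here alone, is whether the nitrogen keeps this level with other groups on it, such as a plain benzyl, an acetyl or no substituent at all, leaving the free ring amine. Also open, going by these compounds, is what happens when the isopropyl on the oxadiazole gives way to a cyclopropyl or a tert-butyl.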